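Working notes: aromatic nitrogen substituent swap, compounds 2 and 3

The source may report more compounds than this note shows. Statements on the series, on what has been measured and on what is new or still open speak of the compounds shown alone.

Two compounds of the series have been run in an assay on isolated protein for inhibition of kinesin heavy chain isoform 5A (Homo sapiens); a higher number here means a weaker inhibitor, a lower number a stronger inhibitor. Compound 1 `COc1ccc(Nc2nc3cc(C(=O)Nc4ccccc4OC)ccc3n2Cc2ccccc2C(F)(F)F)cc1` gives only a limit in this assay, > 50000 nM. Compound 2 `NC(=O)c1ccc2c(c1)nc(Nc1ccc(S(N)(=O)=O)cc1)n2C1(c2ccccc2)CC1` likewise gives only a limit in this assay, > 50000 nM. Compound 2 therefore stands at the limit of > 50000 nM in this assay, at which 2 of the 2 values shown sit, and no number is known for it. For the measured compounds named here, no step between measured compounds can be drawn; all that the two values show is that neither compound 1 nor compound 2 reaches measurable inhibition in this assay.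

Compound 3 `NC(=O)c1ccc2c(c1)nc(Nc1ccc(S(N)(=O)=O)cc1)n2Cc1nc2ccccc2s1` is the next compound to be measured in this assay. It differs from compound 2 in one place: (1,3-benzothiazol-2-yl)methyl in place of 1-phenylcyclopropyl on an aromatic nitrogen. With compound 2 at a limit, no direction beyond the scatter can be read from the numbers shown. The expected step of a number no higher from compound 2 to compound 3 (the limit leaves the size open) is set at none beyond the scatter. Compound 3 is expected most likely to return a limit as well. The estimate for compound 3 in this assay is 50000 nM, with a range from 15000 nM to 100000 nM.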

Compound 3, half-maximal inhibitory concentration: > 50000 nM
Compound 3 gave a limit, no number; the forecaster's own chance of this, stated with the estimate: 70%; the middle value lies on the limit itself.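

Compound 3 gives only a limit, > 50000 nM. Compound 2 also stands at a limit, so no step can be read between compound 2 and compound 3, and the series shows a single result: the limit of > 50000 nM in this assay, at which 3 of the 3 values shown sit.

The compounds shown leave open whether any substituent on the aromatic nitrogen of the shared core gives measurable inhibition.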